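Cytotoxicity of an indole sulfone amide series in MT4 cells

The source may report more compounds than this note shows. Statements on the series, on what has been measured and on what is new or still open speak of the compounds shown alone.

Compound 2 `Cc1cc(C)cc(S(=O)(=O)c2c(C(=O)NC3CN(Cc4cccnc4)C3)[nH]c3ccc(Cl)cc23)c1` was assessed in an ADME assay on MT4 cells (Homo sapiens) for cytotoxicity, read by MTT assay, with a stated time of 5 days (a lower number here means that less compound is tolerated, a higher number that more compound is tolerated), where compound 2 gives 36000 nM. Within the data shown here, this is the lowest of the two numbers measured so far, yet its only neighbour sits within the scatter: compound 1 `Cc1cc(C)cc(S(=O)(=O)c2c(C(=O)N[C@@H]3CCNC3)[nH]c3ccc(Cl)cc23)c1` gives 37300 nM in this assay, and the step of a 1.0-fold lower number from compound 1 to compound 2 (0.02 log units; within the scatter) shows no real difference. Compound 3 `Cc1cc(C)cc(S(=O)(=O)c2c(C(=O)NS(=O)(=O)c3ccc(F)cc3F)[nH]c3ccc(Cl)cc23)c1` has not been measured. It differs from compound 2 at the amide-type nitrogen: (2,4-difluorophenyl)sulfonyl in place of 1-((pyridin-3-yl)methyl)azetidin-3-yl on an amide-type nitrogen. Among the measured compounds shown here, the one measured step concerned a different swap on the same nitrogen and stayed within the scatter, so nothing measured here argues for a large move in this assay. Compound 3 is therefore expected to land close to compound 2, with an estimated step of a 1.0-fold lower number from compound 2 to compound 3 (0.01 log units; within the scatter). The estimate for compound 3 is 35000 nM, with a range from 14000 nM to 90000 nM.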

Compound 3, half-maximal cytotoxic concentration: 121000 nM
Estimate against measurement, compound 3: 3.5-fold (0.54 log units) below; measured number outside the range, above it.
By their numbers in this assay, from the lowest: compounds 2 and 1 (each within the scatter of the next); then compound 3.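

At the amide-type nitrogen, the substituent can move the number in this assay: (2,4-difluorophenyl)sulfonyl in place of 1-((pyridin-3-yl)methyl)azetidin-3-yl gives a 3.4-fold higher number from compound 2 to compound 3 (0.53 log units; beyond the scatter) and the same group in place of pyrrolidin-3-yl gives a 3.2-fold higher number from compound 1 to compound 3 (0.51 log units; beyond the scatter). The earlier pair had stayed within the scatter, so this position showed a modest response only once the sulfonyl group entered. The leaving and entering groups of the step from compound 2 have equal counts of heavy atoms and of hydrogen-bond acceptors, so these counts do not separate them.

Nothing available accounts for the rise. Going by these compounds, it remains open whether the sulfonyl link or the difluorophenyl ring carries the step, which a benzoyl or methylsulfonyl group on the same nitrogen could help to separate.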